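The source may hold more compounds than are shown below. What is called first, only, known or untested is meant among the compounds shown, and "the series" means these compounds.

Compound 1, `COc1cc(C(=O)O)ccc1OCCCCOc1ccc(C(=O)C(C)C)c(O)c1C`, gives 73.1% in an assay on HEK293 cells for positive allosteric modulation of metabotropic glutamate receptor 2 (Rattus norvegicus), read by thallium flux, with a stated time of 2.5 min; on this read-out lower numbers stand for smaller maximal responses and higher numbers for larger maximal responses.
Compound 2, `Cc1c(OCCCCOc2ccc(C(=O)O)cc2)ccc(C(=O)CC2CCCC2)c1O`, gives 82.6% in this assay.
Compound 3, `Cc1c(OCCCCOc2ccccc2C(=O)O)ccc(C(=O)CC2CCCC2)c1C`, gives 67.1% in this assay.

Of these three numbers, compound 2 has the highest. Compound 1 comes nearest to it, and the gap between the two lies within the usual scatter of repeated measurements, so the two cannot be told apart. Compound 3 lies furthest away, and that gap is beyond the scatter, so compound 3 reaches a smaller maximal response than compound 2. Among the compounds with values here, none of the three measured compounds differ from one another in a single place, so no single-change step among them is known.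

Compound 4, `Cc1c(OCCCCOc2ccc(C(=O)O)cc2F)ccc(C(=O)CC2CCCC2)c1O`, has not yet been measured. It differs from compound 2 in one place: fluoro in place of hydrogen on an aromatic carbon. A single fluorine atom entering on the ring that carries the carboxy group is a small change. In this assay no step beyond the scatter is expected, in either direction. The expected step of a number 2.6 percentage points lower from compound 2 to compound 4 (within the scatter) is small. Compound 4 is therefore estimated to reach 80%, within a range from 65% to 95%.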

Compound 4, largest response reached (reported as percent of maximum), in percent of the reference or control that the assay uses: 83.8%
Estimate against measurement, compound 4: 3.8 percentage points below; the range from low to high includes it.
By their numbers in this assay, from the lowest: compounds 3, 1, 2 and 4 (each within the scatter of the next, the first and the last beyond it).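

Within the data shown here, this is the first pair that differs in one place, so the effect of a single change can now be read. In this assay, placing fluoro on an aromatic carbon ortho to a large group and meta to the carboxy group gives a number 1.2 percentage points higher from compound 2 to compound 4 (within the scatter), so compound 2 and compound 4 cannot be told apart, and the maximal response is kept with this fluorine in place. No measurement shown here bears on why the response holds, so nothing about the fluorine atom can be offered as an explanation.

Going by these compounds, whether a chlorine atom or an amino group on this same carbon would also keep the response remains open. A single pair also cannot show whether fluoro on another carbon of this ring would behave in the same way.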